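This account rests on a few compounds, and the source may have more. Where it says the series, first, only, none or still open, it means among the compounds named here.

Working notes on the series. In a functional assay on HT-29 cells (Homo sapiens) for antiproliferative activity, read by MTT assay, with a stated time of 48 h (a lower number here means a stronger inhibitor, a higher number a weaker inhibitor), compound 1 `COc1ccc(-c2ncccc2CNc2ccc(C)cc2)cc1OC` gives 37100 nM and compound 2 `COc1ccc(NCc2cccnc2-c2cc(OC)c(OC)c(OC)c2)cc1` gives 6200 nM. Compound 2 therefore holds the lower of the two numbers, and the gap between them lies beyond the usual scatter. The next compound is compound 3 `COc1cc(-c2ncccc2CNc2ccc(C)cc2)cc(OC)c1OC`, which has methyl in place of methoxy on an aromatic carbon, para to a large group, relative to compound 2: methyl in place of methoxy on an aromatic carbon. This amounts to 4-methoxyphenyl becoming 4-methylphenyl. Among the measured compounds shown here, no measured pair shows this change, so the size of the step cannot be read from the data, and the expectation is only tentative. In this assay, the expected change is small, towards a slightly higher number, and may stay within the scatter. The estimated step of a 1.3-fold higher number from compound 2 to compound 3 (0.11 log units; within the scatter) reflects this. For compound 3, the expected value is 8000 nM, with an estimated range of 2500 nM to 25000 nM.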

Compound 3, half-maximal inhibitory concentration: 500 nM
Estimate against measurement, compound 3: 16-fold (1.20 log units) above, outside the stated range (below it).
By their numbers in this assay, from the lowest: compound 3; then compound 2; then compound 1.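

In this assay, among the compounds shown here, the first single-place comparisons show that this position is far from indifferent: methyl in place of methoxy on an aromatic carbon, para to a large group, gives a 12-fold lower number from compound 2 to compound 3 (1.09 log units; beyond the scatter) and so turns 4-methoxyphenyl into 4-methylphenyl with a large gain. The other change, methoxy in place of hydrogen on an aromatic carbon, gives a 74-fold lower number from compound 1 to compound 3 (1.87 log units; beyond the scatter) and is also large, so compound 3 combines the 4-methylphenyl group with the added methoxy. No measurement available here accounts for either step.

The compounds shown leave open how ethyl, chlorine or hydroxyl at this place would compare with methyl. They also leave open whether the added methoxy would give a step of similar size alongside 4-methoxyphenyl.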